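The compounds below may be only part of what the source reports. "The series", "measured", "known", "first", "only" and "open" are said of these compounds alone.

Compound 1 `Cc1cccnc1-c1cnc(C(=O)CCCCCCc2ccccc2)o1`: in an assay (Rattus norvegicus) for inhibition of Fatty-acid amide hydrolase 1 (Homo sapiens) (on this read-out higher numbers stand for weaker inhibition and lower numbers for stronger inhibition), compound 1 gives 15 nM.
Compound 2 `O=C(CCCCCCc1ccccc1)c1ncc(-c2ncccc2C(=O)O)o1`: in this assay compound 2 reaches only a limit, > 50 nM.
Compound 3 `O=C(CCCCCCc1ccccc1)c1ncc(-c2nnn[nH]2)o1`: in this assay compound 3 gives 63 nM.

Compound 3 stands highest of the two numbers given; the gap to the nearest number is a 4.2-fold higher number from compound 1 to compound 3 (0.62 log units; beyond the scatter). Compound 4 `CC(=O)c1cnc(C(=O)CCCCCCc2ccccc2)o1` is not yet measured; it differs from compound 3 by acetyl in place of 1H-tetrazol-5-yl on an aromatic carbon. For the measured compounds named here, two measured steps bear on this change. Replacing the methyl-bearing ring by the tetrazolyl gave a 4.2-fold higher number from compound 1 to compound 3 (0.62 log units; beyond the scatter), and replacing methyl by carboxy gave an at least 3.3-fold higher number from compound 1 to compound 2 (0.52 log units; beyond the scatter), while a step that the limit leaves unreadable from compound 2 to compound 3. Both readable steps moved away from compound 1, so removing the tetrazolyl is expected to move back toward it, a modest step downward. Compound 4 is therefore expected to give about 22 nM, between 8 nM and 60 nM. That estimate means an expected step of a 2.9-fold lower number from compound 3 to compound 4 (0.46 log units; beyond the scatter).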

Compound 4, inhibition constant: 2 nM
Compound 4: middle estimate off by 11-fold (1.04 log units), on the high side; measured number below the stated range.
By their numbers in this assay, from the lowest: compound 4; then compound 1; then compound 3.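

In this assay, acetyl at this position gives a lower number than either ring group tested there, with steps of a 32-fold lower number from compound 3 to compound 4 (1.50 log units; beyond the scatter) and a 7.5-fold lower number from compound 1 to compound 4 (0.88 log units; beyond the scatter). The step read from a limit, rather than from a number, is an at least 25-fold lower number from compound 2 to compound 4 (1.39 log units; beyond the scatter). The earlier compounds shown here all carried a ring at this position, so they could not show that a low number does not require one.

On these data alone, it remains open whether the carbonyl of acetyl matters or simply the absence of a ring. A methyl ester, an amide or a propanoyl group here would help separate these possibilities.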